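Anilinotriazole series: swapping the second anilino group

This account rests on a few compounds, and the source may have more. Where it says the series, first, only, none or still open, it means among the compounds named here.

Working notes on the series. Among the compounds with values here, all four compounds share one core with two anilino substituents; the compounds measured so far vary only the second one. In a functional assay on A-431 cells (Homo sapiens), tested at 0.1 uM (a higher number here means more inhibition at the concentration tested (going by the name of the read-out), a lower number less inhibition), compound 1 `COc1cc(Nc2ncccc2-c2nc(Nc3cc(OC)ccc3OC)n[nH]2)cc(OC)c1` gives 20%. In this assay compound 2 `COc1cc(Nc2ncccc2-c2nc(Nc3ccc(OC)cc3OC)n[nH]2)cc(OC)c1` gives 17%. The step of a number 3 percentage points lower from compound 1 to compound 2 (within the scatter) lies within the scatter, so the two methoxy patterns are not separable on these numbers.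

Compound 3 `COc1cc(Nc2ncccc2-c2n[nH]c(Nc3ccc(N(C)C)cc3)n2)cc(OC)c1` gives "not determined" (no result reported) in this assay, which is no result at all, so it stands on no number of its own; the only level known for the series is that set by compound 1 and compound 2.

Compound 4 `COc1cc(Nc2ncccc2-c2n[nH]c(Nc3ccc4c(c3)OCCO4)n2)cc(OC)c1` differs from compound 3 by 2,3-dihydro-1,4-benzodioxin-6-yl in place of 4-(dimethylamino)phenyl on a nitrogen on an aromatic ring. Within the data shown here, no measured step bears on this exchange: the single measured step concerns a different anilino group and is within the scatter. There is therefore no basis for expecting a step beyond the scatter in this assay in either direction, and the series level is the only anchor. Compound 4 is estimated to give 20%, with a range from 5% to 40%.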

Compound 4, a percentage reported as inhibition, at one concentration (the size of the read-out at that concentration, not a potency): 83%
The estimate for compound 4 lay 63 percentage points below the measured number; the measured number lies above the stated range.
By their numbers in this assay, from the lowest: compounds 2 and 1 (each within the scatter of the next); then compound 4.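

Within the data shown here, compound 3 has no number in this assay and compound 4 gives 83% there, so no step between them can be read. No available evidence bears on this result.

The compounds shown leave open whether the level of compound 4 belongs to the 2,3-dihydro-1,4-benzodioxin-6-yl group or would also appear with 4-(dimethylamino)phenyl in its place.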